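The source may report more compounds than this note shows. Statements on the series, on what has been measured and on what is new or still open speak of the compounds shown alone.

In a physicochemical assay for lipophilicity, at pH 7.4 (on this read-out lower numbers stand for lower lipophilicity and higher numbers for higher lipophilicity), compound 1 (`CCc1ccc(N(CC2CCC2)S(=O)(=O)c2ccc3c(c2)C(=O)CC(C2CCOCC2)O3)cc1`) gives 4.1, compound 3 (`CC(C)CN(c1cc2ccccc2s1)S(=O)(=O)c1ccc2c(c1)C(=O)CC(C1CCOCC1)O2`) gives 4.01, and compound 2 (`CCc1ccc(N(CC(C)C)S(=O)(=O)c2ccc3c(c2)C(=O)CC(CC2CCOCC2)O3)cc1`) gives 4.53. Compound 2 is the highest of the three, and its gaps to the other two lie beyond the scatter. Compound 4 (`CCc1ccc(N(CC(C)C)S(=O)(=O)c2ccc3c(c2)C(=O)CC(c2c(C)noc2C)O3)cc1`) has not yet been measured. It differs from compound 2 in one place, on a saturated ring carbon next to the ring oxygen: 3,5-dimethyl-1,2-oxazol-4-yl in place of (oxan-4-yl)methyl on a saturated ring carbon. Among the measured compounds shown here, no measured pair isolates a change at this place, so the expectation rests loosely on compound 2 at 4.53. A slight fall is expected, with the estimated step of a number 0.13 log units lower from compound 2 to compound 4 (within the scatter) staying within the scatter in this assay. The estimate for compound 4 is 4.4, with an expected range of 3.9 to 4.9.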

Compound 4, distribution coefficient: 4.42
Compound 4: the middle estimate sits 0.02 log units below what was measured; low and high end bracket the measured number.
By their numbers in this assay, from the lowest: compounds 3 and 1 (each within the scatter of the next); then compounds 4 and 2 (each within the scatter of the next).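

In this assay, among the compounds shown here, the first isolated change on a saturated ring carbon next to the ring oxygen gives only a small step (a number 0.11 log units lower from compound 2 to compound 4 (within the scatter)). This position therefore accepts a five-membered aromatic ring with 2 hetero atoms in place of the (oxan-4-yl)methyl group, with its six-membered non-aromatic ring, without a change beyond the scatter. Nothing available explains this result. From the compounds shown here alone, whether an amine or a carboxylic acid at this place would give a step beyond the scatter remains open. So does the outcome for a longer chain.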